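The source may report more compounds than this note shows. Statements on the series, on what has been measured and on what is new or still open speak of the compounds shown alone.

Compound 1 `COc1ccc(C)cc1N1C(=O)CSC1c1cccc(C(=O)NCCCCc2ccccc2)c1`: 300 nM
Compound 2 `COc1ccc(F)cc1N1C(=O)CSC1c1cccc(C(=O)NCCCCc2ccccc2)c1`: 8.8 nM

In a functional assay on HOS-TE85 cells (Homo sapiens) for inhibition, read by CCK-8 assay, with a stated time of 72 h (a lower number here means a stronger inhibitor, a higher number a weaker inhibitor), compound 2 has the lower of the two numbers, at 8.8 nM. Among the measured compounds shown here, the only measured step, a 34-fold lower number from compound 1 to compound 2 (1.53 log units; beyond the scatter), is large and comes from fluoro in place of methyl on an aromatic carbon. Compound 3 `O=C(NCCCCc1ccccc1)c1cccc(C2SCC(=O)N2c2cccc(-c3c[nH]nn3)c2)c1` has not yet been measured. Its change from compound 2 is a group of 11 heavy atoms (8 carbon, 3 nitrogen; one five-membered aromatic ring with 3 hetero atoms, one six-membered aromatic ring of carbon only) in place of a group of 9 heavy atoms (7 carbon, 1 oxygen, 1 fluorine; one six-membered aromatic ring of carbon only), on an amide-type nitrogen in a ring, on an amide-type nitrogen in a ring, so the whole 5-fluoro-2-methoxyphenyl group leaves. For the measured compounds named here, the step of a 34-fold lower number from compound 1 to compound 2 (1.53 log units; beyond the scatter) bears on this only indirectly: it shows that one edit to this group can move the number far, but no measured compound carries the entering group. A higher number is expected, with a rise smaller than that step and a wide uncertainty. The expected change is a 5.7-fold higher number from compound 2 to compound 3 (0.75 log units; beyond the scatter). For compound 3 the estimated value is 50 nM, with an expected range of 6 nM to 400 nM.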

Compound 3, half-maximal inhibitory concentration: 110 nM
Beside the measured number, compound 3's estimate is 2.2-fold (0.34 log units) below it; low and high end bracket the measured number.
By their numbers in this assay, from the lowest: compound 2; then compound 3; then compound 1.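

In this assay, the whole 5-fluoro-2-methoxyphenyl group on the amide-type nitrogen in a ring can be exchanged for a group holding one five-membered aromatic ring with 3 hetero atoms at a clear cost, a 13-fold higher number from compound 2 to compound 3 (1.10 log units; beyond the scatter). The same entering group still improves on the methyl-bearing group of compound 1, with a 2.7-fold lower number from compound 1 to compound 3 (0.44 log units; beyond the scatter), so the position accepts a group with no oxygen or fluorine and places compound 3 between the two earlier compounds. Nothing measured here accounts for either step.

From the compounds shown here alone, it remains open how much of this result belongs to the five-membered aromatic ring itself, and how a carboxylic acid or a primary amine would compare in its place. The compounds also leave open whether a fluoro on the six-membered aromatic ring of compound 3 would lower its number.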